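The compounds below may be only part of what the source reports. "The series", "measured", "known", "first", "only" and "open" are said of these compounds alone.

Measured so far in an ADME assay on microsomes from liver (Homo sapiens) for metabolic stability (a lower number here means slower removal, a higher number faster removal of the compound), for the series:
Compound 1 (`CCn1cnc2c(-c3ccc(F)c(-c4cnn(C)c4)c3)cnnc21`) gives 47 mL.min-1.g-1
Compound 2 (`CCn1cnc2c(-c3ccnc(Oc4ccccc4)c3)cnnc21`) gives 51 mL.min-1.g-1
Compound 3 (`CCn1cnc2c(-c3ccc(F)c(OCc4ccccn4)c3)cnnc21`) gives 41 mL.min-1.g-1

Compound 3 at 41 mL.min-1.g-1 sits within the scatter of both other compounds, so these three values give no order. The next compound is compound 4 (`CCn1cnc2c(-c3ccc(F)c(-c4ccnc(C)c4)c3)cnnc21`), which carries 2-methylpyridin-4-yl in place of (pyridin-2-yl)methoxy on an aromatic carbon, ortho to a fluoro group (2-methylpyridin-4-yl in place of (pyridin-2-yl)methoxy on an aromatic carbon). Among the measured compounds shown here, the step of a 1.1-fold lower number from compound 1 to compound 3 (0.06 log units; within the scatter) is the only measured change at this place and stays within the scatter, with (pyridin-2-yl)methoxy replacing 1-methyl-1H-pyrazol-4-yl. For the measured compounds named here, compound 2 provides no measured single-place step to compound 3 and so adds only its value to the picture. Going by the values given here, no measured compound carries 2-methylpyridin-4-yl, so the expectation rests on one small step and on the narrow spread of three values. No step beyond the scatter is therefore expected in this assay in either direction. The estimated step is a 1.1-fold higher number from compound 3 to compound 4 (0.04 log units; within the scatter) and is expected to lie within the scatter. For compound 4 the expected value is 45 mL.min-1.g-1 with an estimated range from 25 mL.min-1.g-1 to 80 mL.min-1.g-1 for a measurement of this kind.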

Compound 4, intrinsic clearance in microsomes: 157 mL.min-1.g-1
Compound 4: middle estimate off by 3.5-fold (0.54 log units), on the low side; measured number above the stated range.
By their numbers in this assay, from the lowest: compounds 3, 1 and 2 (each within the scatter of the next); then compound 4.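

In this assay, among the compounds shown here, the place ortho to a fluoro group now proves able to shift the number: 2-methylpyridin-4-yl gives a 3.8-fold higher number from compound 3 to compound 4 (0.58 log units; beyond the scatter) and, against the other group, a 3.3-fold higher number from compound 1 to compound 4 (0.52 log units; beyond the scatter) while the only earlier step here stayed within the scatter (a 1.1-fold lower number from compound 1 to compound 3 (0.06 log units; within the scatter)). Compound 1 and compound 3 lie within the scatter of each other. Both steps into compound 4 point to the entering 2-methylpyridin-4-yl rather than to which group leaves, and compound 1 shows that an aromatic ring attached directly at this place does not by itself go with the high number. The data shown offer no measurement that accounts for the jump, so the difference between the two directly attached rings remains unexplained.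

As far as these compounds go, whether the higher number goes with the methyl group or with the pyridine ring of 2-methylpyridin-4-yl stays open, and a plain pyridin-4-yl or a 2-methoxypyridin-4-yl at this place would separate the two. Also open, from the compounds shown here alone, is whether a saturated amine such as morpholine at this place would stay with compound 1 and compound 3 or move toward compound 4.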